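Compound 4: fluoro and ethoxy replace hydroxy and methoxy

The source may hold more compounds than are shown below. What is called first, only, known or untested is meant among the compounds shown, and "the series" means these compounds.

Measured in a functional assay on A549 cells (Homo sapiens) for antiproliferative activity, read by MTT assay, with a stated time of 48 h; a lower number here means a stronger inhibitor, a higher number a weaker inhibitor:
Compound 1 `COc1ccc(-c2cncc3[nH]c(=O)n(Cc4cc(OC)c(OC)c(OC)c4)c23)cc1O` gives > 20000 nM (a limit)
Compound 2 `COc1ccc(-c2cc3c(cn2)[nH]c(=O)n3-c2cc(OC)c(OC)c(OC)c2)cc1F` gives 2020 nM
Compound 3 `COc1ccc(-c2cc3c(cn2)[nH]c(=O)n3-c2cc(OC)c(OC)c(OC)c2)cc1O` gives 630 nM

Compound 3 has the lower of the two exact numbers in this assay. The entry for compound 1 is a limit, not a number. Compound 4 `CCOc1ccc(-c2cc3c(cn2)[nH]c(=O)n3-c2cc(OC)c(OC)c(OC)c2)cc1F` differs from compound 3 by 4-ethoxy-3-fluorophenyl in place of 3-hydroxy-4-methoxyphenyl on an aromatic carbon. Among the measured compounds shown here, the one measured step that bears on this is a 3.2-fold lower number from compound 2 to compound 3 (0.51 log units; beyond the scatter), a modest step for hydroxy in place of fluoro. Compound 4 has fluoro rather than hydroxy, so a step of similar size toward a higher number is expected. For the measured compounds named here, no measured step covers ethoxy. The expected step is a 4.4-fold higher number from compound 3 to compound 4 (0.65 log units; beyond the scatter). Compound 4 is estimated at 2800 nM, with an expected range of 1000 nM to 8000 nM.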

Compound 4, half-maximal inhibitory concentration: 2540 nM
Compound 4: the middle estimate sits 1.1-fold (0.04 log units) above what was measured, and the stated range covers the measured number.
By their numbers in this assay, from the lowest: compound 3; then compounds 2 and 4 (each within the scatter of the next). At a limit, above all of these: compound 1.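

In this assay, among the compounds shown here, ethoxy in place of methoxy alongside the fluoro group gives a 1.3-fold higher number from compound 2 to compound 4 (0.10 log units; within the scatter) with no change beyond the scatter, which the earlier compounds could not show. The full change on this ring gives a 4.0-fold higher number from compound 3 to compound 4 (0.61 log units; beyond the scatter) and leaves compound 4 with compound 2, on the fluoro side of the hydroxy-to-fluoro difference. Nothing shown here gives a reason for these steps. As far as these compounds go, whether a propoxy chain would also leave the number unchanged stays open. So does whether an amine in place of the fluoro would behave like the hydroxy of compound 3.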